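A few compounds are considered here, and "the series" means these few. Any claim that something is new, unique, unknown or untested is made for them only; others in the source may bear on it.

Of the compounds shown here, three sharing one core have been measured in an assay on membranes from CHO cells for displacement of a labelled ligand from adenosine receptor A1 (Homo sapiens), read by scintillation counting, with a stated time of 60 min, tested at 1 uM; on this read-out higher numbers stand for more inhibition at the one concentration tested (going by the name of the read-out) and lower numbers for less inhibition. Compound 1 `CCSC(=O)C1=C(C)NC(=O)NC1c1ccoc1` carries an ethylsulfanyl group on the carbonyl carbon, and in this assay compound 1 gives 3%. Compound 2 `CCC(CC)OC(=O)C1=C(C)NC(=O)NC1c1ccoc1` has (pentan-3-yl)oxy in place of ethylsulfanyl on that carbonyl carbon, and compound 2 gives 17%. Compound 3 `CCC(C)OC(=O)C1=C(C)NC(=O)NC1c1ccoc1` has sec-butoxy there instead, and compound 3 gives 13%. Compound 3 thus stands second highest of the three numbers, with its gaps to compound 2 and to compound 1 both inside the usual scatter. The steps read a number 14 percentage points higher from compound 1 to compound 2 (beyond the scatter), a number 10 percentage points higher from compound 1 to compound 3 (within the scatter) and a number 4 percentage points lower from compound 2 to compound 3 (within the scatter).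

Compound 4 `CC1=C(C(=O)OCC2CCC2)C(c2ccoc2)NC(=O)N1` has not yet been measured. It differs from compound 3 in one place: cyclobutylmethyl in place of sec-butyl on an oxygen next to a carbonyl group. Among the compounds with values here, the step bearing most directly on this is the one between compound 2 and compound 3, where only the group on the oxygen next to a carbonyl group changed and the result was a number 4 percentage points lower from compound 2 to compound 3 (within the scatter). The two steps from compound 1 replaced ethylsulfanyl with an alkoxy group, a different kind of change, and were modest at most. A step no larger than the scatter is therefore expected for compound 4, the estimate meaning a number 2 percentage points higher from compound 3 to compound 4 (within the scatter). Compound 4 is expected to give about 15%, within a range from 3% to 30%.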

Compound 4, a percentage reported as inhibition, at one concentration (the size of the read-out at that concentration, not a potency): 46%
Estimate against measurement, compound 4: 31 percentage points below; measured number outside the range, above it.
By their numbers in this assay, from the lowest: compounds 1, 3 and 2 (each within the scatter of the next, the first and the last beyond it); then compound 4.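

In this assay, the group on the oxygen next to a carbonyl group proves able to shift the number well beyond the scatter: cyclobutylmethyl in place of sec-butyl gives a number 33 percentage points higher from compound 3 to compound 4 (beyond the scatter), and cyclobutylmethyl in place of pentan-3-yl gives a number 29 percentage points higher from compound 2 to compound 4 (beyond the scatter), whereas the earlier change between the two ring-free groups stayed within the scatter. Cyclobutylmethoxy in place of ethylsulfanyl on a carbonyl carbon gives a number 43 percentage points higher from compound 1 to compound 4 (beyond the scatter), and among these compounds cyclobutylmethyl is the only group on that oxygen with a four-membered non-aromatic ring of carbon only, so the higher number goes with that ring here, though one compound cannot establish a trend. No measurement shown here explains why this group gives the higher number.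

On these data alone, it remains open whether the ring itself matters or how it is attached, which cyclobutyl placed directly on the oxygen, cyclopentylmethyl or an unbranched pentyl chain could help to separate. As far as these compounds go, a percentage at one concentration is also not a potency, so how strongly compound 4 binds remains unknown.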